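Swapping trifluoromethyl for chloro on a urea aryl ring

The compounds below may be only part of what the source reports. "The series", "measured", "known", "first", "only" and "open" are said of these compounds alone.

Measured so far:
- compound 1, `O=C(Nc1cccc(-n2cc(-c3ccncc3)c(-c3cc(O)cc(Cl)c3)n2)c1)Nc1ccc(Cl)c(Cl)c1`: 9%
- compound 2, `COc1cc(Cl)cc(-c2nn(-c3cccc(NC(=O)Nc4ccc(Cl)c(C(F)(F)F)c4)c3)cc2-c2ccncc2)c1`: -6%

In a functional assay on Hs-578T cells (Homo sapiens) for inhibition, read by sulforhodamine B assay, with a stated time of 48 h, tested at 100 uM (a lower number here means a stronger effect, a higher number a weaker effect of the compound at the concentration tested), compound 2 gives -6%, the lower of the two numbers, and compound 1 sits higher, a gap beyond the usual scatter. Compound 3, `COc1cc(Cl)cc(-c2nn(-c3cccc(NC(=O)Nc4ccc(Cl)c(Cl)c4)c3)cc2-c2ccncc2)c1`, has not been measured. It differs from compound 2 in one place: chloro in place of trifluoromethyl on an aromatic carbon. Among the compounds with values here, compound 1 also carries a 3,4-dichlorophenyl group, but no single-change step links it to compound 2, so its value only shows that such a group is compatible with a low read-out in this assay. For the step from compound 2 to compound 3 the expectation is a number 8 percentage points higher from compound 2 to compound 3 (within the scatter), a small change that stays within the scatter. Compound 3 is therefore expected to give about 2% in this assay, with a range from -12% to 16%.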

Compound 3, a percentage reported as activity, at one concentration (the size of the read-out at that concentration, not a potency): 28%
For compound 3 the middle estimate is 26 percentage points below the measured one, outside the stated range (above it).
By their numbers in this assay, from the lowest: compound 2; then compound 1; then compound 3.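

In this assay, chloro and trifluoromethyl are not interchangeable on this ring: the swap gives a number 34 percentage points higher from compound 2 to compound 3 (beyond the scatter), so the weaker effect goes with chloro at this one place on the urea aryl ring. The far side of the molecule counts as well, since with the 3,4-dichlorophenyl group held constant, methyl in place of hydrogen on the oxygen gives a number 19 percentage points higher from compound 1 to compound 3 (beyond the scatter). Nothing available here explains why either change moves the read-out.

The compounds shown leave open whether a nitrile, a methyl or a bromo at this place would track compound 2 or compound 3. They also leave open how a longer chain such as ethyl on the oxygen would read, and whether these steps would hold at other concentrations.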